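Fluoro in place of hydrogen: notes on compound 3

This account rests on a few compounds, and the source may have more. Where it says the series, first, only, none or still open, it means among the compounds named here.

Measured so far in a functional assay on MCF7 cells (Homo sapiens) for cytotoxicity, with a stated time of 48 h; on this read-out lower numbers stand for stronger inhibition and higher numbers for weaker inhibition
compound 1 (`COc1cc(OC)c(C(=O)/C=C/c2ccccc2OC)c(OC)c1`) gives 8900 nM
compound 2 (`COc1cc(OC)c(C(=O)/C=C/c2ccccc2)c(OC)c1`) gives 9400 nM

Among the compounds with values here, compound 2 lies within the scatter of compound 1, the only other measured compound, so the two values carry no order (a 1.1-fold higher number from compound 1 to compound 2 (0.02 log units; within the scatter)). Compound 3 (`COc1cc(OC)c(C(=O)/C=C/c2ccc(F)cc2)c(OC)c1`) is unmeasured and differs from compound 2 in one place (fluoro in place of hydrogen on an aromatic carbon): fluoro in place of hydrogen on an aromatic carbon, para to a large group. Within the data shown here, the sole measured step (a 1.1-fold higher number from compound 1 to compound 2 (0.02 log units; within the scatter)) puts hydrogen in place of methoxy, so it bears only indirectly, and no measured step involves fluoro. No step beyond the scatter is therefore expected in this assay, and no direction can be argued. The estimated step is expected to stay small (a 1.1-fold lower number from compound 2 to compound 3 (0.04 log units; within the scatter)) on this evidence. Compound 3 is estimated at 8500 nM with an expected range from 3500 nM to 20000 nM in this series.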

Compound 3, half-maximal inhibitory concentration: 7700 nM
Estimate against measurement, compound 3: 1.1-fold (0.04 log units) above; the measured number falls inside the stated range.
By their numbers in this assay, from the lowest: compounds 3, 1 and 2 (each within the scatter of the next).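

In this assay, the change from phenyl to 4-fluorophenyl gives a step within the scatter (a 1.2-fold lower number from compound 2 to compound 3 (0.09 log units; within the scatter)), so fluoro in place of hydrogen, para to a large group, separates nothing here. The exchange of 2-methoxyphenyl for 4-fluorophenyl is also within the scatter (a 1.2-fold lower number from compound 1 to compound 3 (0.06 log units; within the scatter)), so phenyl, 2-methoxyphenyl and 4-fluorophenyl on this chain carbon remain unordered on this read-out. No accompanying data offer an account of these results.

Whether any replacement on this aromatic ring can produce a step beyond the scatter remains open, since hydrogen, methoxy and fluoro are the only groups shown on it. As far as these compounds go, an amine or a carboxylic acid para to the large group would test that question, and the shared core remains untested by these compounds.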